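Cytotoxicity limit and the 1-hydroxyethyl step

The compounds below may be only part of what the source reports. "The series", "measured", "known", "first", "only" and "open" are said of these compounds alone.

Of the compounds shown here, two on the shared core have been read so far: compound 1 `CCCCNc1nc(N)nc2cc(C(N)=O)ccc12` and compound 2 `CCCCNc1nc(N)nc2ccc(CO)cc12`. In an ADME assay on HEK293 cells (Homo sapiens) for cytotoxicity, with a stated time of 6 h (on this read-out higher numbers stand for lower toxicity in this test and lower numbers for higher toxicity in this test), compound 1 gives > 18000 nM, which is a limit of the assay and not a number. In this assay compound 2 gives > 18000 nM, which is likewise a limit and not a number. Both readings therefore stand at the limit of > 18000 nM in this assay, at which 2 of the 2 values shown sit, and compound 2 has no exact position on this scale.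

Compound 3 `CCCCNc1nc(N)nc2ccc(C(C)O)cc12` differs from compound 2 by methyl in place of hydrogen on a saturated chain carbon bound to an aromatic carbon and an oxygen on a saturated carbon, which reads as hydroxymethyl to 1-hydroxyethyl. Going by the values given here, no measured step is available to size this change. The expectation in this assay rests on compound 2 alone, with its limit of > 18000 nM. The expected step that the limit leaves unreadable from compound 2 to compound 3 has no clear direction and stays within the scatter. Compound 3 is estimated at 20000 nM, with an expected range of 9000 nM to 40000 nM.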

Compound 3, half-maximal cytotoxic concentration: > 18000 nM
Compound 3: only a limit was reported; the forecaster's own chance of this, stated with the estimate: 80%; the middle value does not contradict the limit.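

No step can be read from compound 2 to compound 3 in this assay, since both readings are limits and not numbers: the limit of > 18000 nM in this assay, at which 3 of the 3 values shown sit.

The compounds shown leave open where compound 1, compound 2 and compound 3 stand on this scale, and whether hydroxymethyl to 1-hydroxyethyl alters the read-out at all.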